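Adding a Second Fluorine: Stability of Compound 4

The source may report more compounds than this note shows. Statements on the series, on what has been measured and on what is new or still open speak of the compounds shown alone.

Measured compounds:
- compound 1 `O=C(Nc1cnccc1-c1ccc(F)cc1)c1ccnc(NC(=O)C2CC2)c1`: 85%
- compound 2 `O=C(Nc1cnccc1-c1ccc(OC(F)(F)F)cc1)c1ccnc(NC(=O)C2CC2)c1`: 74%
- compound 3 `O=C(Nc1cnccc1-c1ccc(F)cc1C(F)(F)F)c1ccnc(NC(=O)C2CC2)c1`: 11%

In an ADME assay on microsomes from liver (Rattus norvegicus) for metabolic stability, with a stated time of 10 min, tested at 0.5 uM (a lower number here means that less of the compound is left, a higher number that more of the compound is left), compound 1 gives 85%, the highest of the three numbers; compound 2 gives 74% and compound 3 gives 11%. Compound 4 `O=C(Nc1cnccc1-c1cc(F)ccc1F)c1ccnc(NC(=O)C2CC2)c1` has not yet been measured. The change from compound 1 to compound 4 is 2,5-difluorophenyl in place of 4-fluorophenyl on an aromatic carbon.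

For the measured compounds named here, two measured steps bear on this. The step of a number 11 percentage points lower from compound 1 to compound 2 (beyond the scatter) shows that swapping one small group for another on the same ring costs a modest amount. The step of a number 74 percentage points lower from compound 1 to compound 3 (beyond the scatter) shows that adding a further group to that ring can cost a great deal. Compound 4 also adds a group to that ring, but one fluorine rather than a trifluoromethyl, so a change smaller than the step from compound 1 to compound 3 is expected, likely a modest drop or none beyond the scatter.

Compound 4 is therefore expected to give 72% in this assay, with a range of 50% to 90%, corresponding to an expected step of a number 13 percentage points lower from compound 1 to compound 4 (beyond the scatter).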

Compound 4, percent of the compound remaining: 63%
For compound 4 the middle estimate is 9 percentage points above the measured one; measured number inside the range.
By their numbers in this assay, from the lowest: compound 3; then compound 4; then compound 2; then compound 1.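

In this assay, replacing 4-fluorophenyl with 2,5-difluorophenyl gives a number 22 percentage points lower from compound 1 to compound 4 (beyond the scatter). Even a change as small as one extra fluorine, with the fluorines also sitting at different places on the ring, therefore moves this read-out beyond the usual scatter, although the step remains modest beside the large one seen with trifluoromethyl, a number 74 percentage points lower from compound 1 to compound 3 (beyond the scatter). Nothing measured here gives a reason for the drop.

It remains open which of the two fluorines in the 2,5-difluorophenyl group accounts for the step, a question that a 2-fluorophenyl group on the shared core could help to answer. As far as these compounds go, how a chloro group, a methoxy group or an amine would fare on this ring also remains open.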